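One Added Fluorine: Expecting Little Change in Cytotoxicity

A few compounds are considered here, and "the series" means these few. Any claim that something is new, unique, unknown or untested is made for them only; others in the source may bear on it.

Compound 1 `Cc1ccc(-n2nc(C(=O)Nc3ccc(Oc4ncnc5ccsc45)cc3)c(C)cc2=O)cc1` gives 25000 nM.
Compound 2 `Cc1cc(=O)n(-c2ccc(F)c(F)c2)nc1C(=O)Nc1ccc(Oc2ncnc3ccsc23)cc1` gives 9230 nM.
Compound 3 `Cc1ccc(-n2nc(C(=O)Nc3ccc(Oc4ncnc5ccsc45)cc3)c(C)cc2=O)c(C)c1` gives 17900 nM.

In a functional assay on HepG2 cells (Homo sapiens) for cytotoxicity, read by MTT assay, with a stated time of 72 h (on this read-out higher numbers stand for weaker inhibition and lower numbers for stronger inhibition), compound 2 carries the lowest of the three numbers. Its separation from compound 1 is real: a 2.7-fold lower number from compound 1 to compound 2 (0.43 log units; beyond the scatter). Its separation from compound 3 is not: a 1.9-fold higher number from compound 2 to compound 3 (0.29 log units; within the scatter) lies within the scatter, so the two cannot be ranked against each other.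

Compound 4 `Cc1cc(=O)n(-c2ccc(F)c(F)c2)nc1C(=O)Nc1ccc(Oc2ncnc3ccsc23)c(F)c1` differs from compound 2 by fluoro in place of hydrogen on an aromatic carbon. Among the measured compounds shown here, none of the measured steps touches this part of the structure: a 2.7-fold lower number from compound 1 to compound 2 (0.43 log units; beyond the scatter) and a 1.9-fold higher number from compound 2 to compound 3 (0.29 log units; within the scatter) swap the group on the aromatic nitrogen, and a 1.4-fold lower number from compound 1 to compound 3 (0.15 log units; within the scatter) adds a methyl there. With no comparable change on record, no step beyond the scatter is expected in this assay, in either direction.

Compound 4 is therefore estimated at 9000 nM, with a range from 4000 nM to 20000 nM, which amounts to an expected step of a 1.0-fold lower number from compound 2 to compound 4 (0.01 log units; within the scatter).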

Compound 4, half-maximal inhibitory concentration: 6930 nM
The estimate for compound 4 lay 1.3-fold (0.11 log units) above the measured number; measured number inside the range.
By their numbers in this assay, from the lowest: compounds 4, 2, 3 and 1 (each within the scatter of the next, the first and the last beyond it).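

Among the compounds shown here, compounds 1, 2 and 3 all share this six-membered aromatic ring of carbon only unchanged, so compound 4 gives the first reading of a change there. In this assay, fluoro in place of hydrogen gives a 1.3-fold lower number from compound 2 to compound 4 (0.12 log units; within the scatter), so a single fluorine at this position leaves the number within the scatter. No measurement here bears on the cause of this result.

Going by these compounds, whether a larger group at this position, such as methoxy or an amine, would also leave the number within the scatter stays open. So does the effect of fluoro at the ring's other carbons.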